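From 1-acetylpentyl to 2-hydroxy-1-methylhexyl on the shared core

This account rests on a few compounds, and the source may have more. Where it says the series, first, only, none or still open, it means among the compounds named here.

In a functional assay on L1210 cells (Mus musculus), with a stated time of 48 h (on this read-out higher numbers stand for weaker inhibition and lower numbers for stronger inhibition), compound 1 (`CCOC(=O)Nc1cc(NC(C)C(=O)COc2ccccc2)c([N+](=O)[O-])c(N)n1`) gives 89000 nM, and compound 2 (`CCOC(=O)Nc1cc(NC(C)C(=O)Cc2ccccc2)c([N+](=O)[O-])c(N)n1`) gives 10000 nM. Compound 3 (`CCCCC(Nc1cc(NC(=O)OCC)nc(N)c1[N+](=O)[O-])C(C)=O`) gives 31000 nM, the second highest of the three numbers. Compound 4 (`CCCCC(O)C(C)Nc1cc(NC(=O)OCC)nc(N)c1[N+](=O)[O-]`) carries 2-hydroxy-1-methylhexyl in place of 1-acetylpentyl on a nitrogen on an aromatic ring. For the measured compounds named here, the only measured step, an 8.9-fold lower number from compound 1 to compound 2 (0.95 log units; beyond the scatter), is a different exchange, phenyl in place of phenoxy, so it bears on this change only indirectly, as a modest yardstick. Going by the values given here, no measured step covers this exchange, so no step beyond the scatter is expected in this assay, and no direction is favoured. The expected step is a 1.1-fold higher number from compound 3 to compound 4 (0.05 log units; within the scatter). Compound 4 is estimated at 35000 nM, with an expected range of 11000 nM to 100000 nM.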

Compound 4, half-maximal inhibitory concentration: 55000 nM
For compound 4 the middle estimate is 1.6-fold (0.20 log units) below the measured one, and the stated range covers the measured number.
By their numbers in this assay, from the lowest: compound 2; then compounds 3, 4 and 1 (each within the scatter of the next, the first and the last beyond it).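

In this assay, the exchange to 2-hydroxy-1-methylhexyl adds a hydrogen-bond donor and loses the double bond outside aromatic rings, yet it stays within the scatter (a 1.8-fold higher number from compound 3 to compound 4 (0.25 log units; within the scatter)). The open-chain hydroxyl compound remains clearly apart from the benzylcarbonyl compound (a 5.5-fold higher number from compound 2 to compound 4 (0.74 log units; beyond the scatter)), with 1-hydroxypentyl in place of benzylcarbonyl. No evidence here bears on the cause of either step. Open, going by these compounds, is whether an amine or a carboxylic acid in place of the hydroxyl, or a longer chain, would shift the number beyond the scatter.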